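A few compounds are considered here, and "the series" means these few. Any claim that something is new, unique, unknown or untested is made for them only; others in the source may bear on it.

Compound 1 `COc1ccc(/C=C/c2cc(C)no2)cc1OC`: 87400 nM
Compound 2 `COc1cc(/C=C/c2cc(C)[nH]n2)ccc1O`: 78800 nM
Compound 3 `COc1ccc(/C=C/C(=O)CC(C)=O)cc1OC`: 4700 nM

In a functional assay on HCT-116 cells (Homo sapiens) for cytotoxicity, read by MTT assay, with a stated time of 72 h (a lower number here means a stronger inhibitor, a higher number a weaker inhibitor), compound 1 stands at the weak end of these three, level within the scatter with compound 2, while compound 3 has a much lower number. Compound 4 `COc1ccc(/C=C/c2cc(C)no2)cc1` differs from compound 1 by hydrogen in place of methoxy on an aromatic carbon. Among the measured compounds shown here, the only measured step, a 19-fold lower number from compound 1 to compound 3 (1.27 log units; beyond the scatter), is large, but it changes another place in the molecule. No measurement covers the loss of a methoxy group, so no step beyond the scatter is expected in this assay. The expected change is a 1.2-fold lower number from compound 1 to compound 4 (0.10 log units; within the scatter). For compound 4 the estimated value is 70000 nM, with an expected range from 30000 nM to 160000 nM.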

Compound 4, half-maximal inhibitory concentration: 22400 nM
Beside the measured number, compound 4's estimate is 3.1-fold (0.49 log units) above it; the whole stated range lies above it.
By their numbers in this assay, from the lowest: compound 3; then compound 4; then compounds 2 and 1 (each within the scatter of the next).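

In this assay, the methoxy group on this aromatic carbon, ortho to a methoxy group, is not needed for the cytotoxic effect: hydrogen in its place gives a 3.9-fold lower number from compound 1 to compound 4 (0.59 log units; beyond the scatter), a change beyond the scatter. Among the compounds shown here, the earlier step altered another place in the molecule, so this is the first sign that this position on the ring also affects the number. Nothing available explains the shift. From the compounds shown here alone, whether an amine, a fluorine atom or a longer ethoxy chain on this carbon would lower the number further remains open. So does whether removing this methoxy group from compound 3 would have a similar effect.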